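Moving a Trifluoromethyl Group on a Sulfonyl-Bound Ring

The compounds below may be only part of what the source reports. "The series", "measured", "known", "first", "only" and "open" are said of these compounds alone.

Compound 1 `CC(O)(CS(=O)(=O)c1cccc(C(F)(F)F)c1)C(=O)Nc1ccc(S(F)(F)(F)(F)F)cc1` and compound 2 `CC(O)(CS(=O)(=O)c1ccccc1C(F)(F)F)C(=O)Nc1ccc(S(F)(F)(F)(F)F)cc1` share one core, while compound 3 `CC(O)(CS(=O)(=O)c1cccc(C(F)(F)F)c1)C(=O)Nc1cccc(S(F)(F)(F)(F)F)c1` and compound 4 `CC(O)(CS(=O)(=O)c1ccccc1C(F)(F)F)C(=O)Nc1cccc(S(F)(F)(F)(F)F)c1` share another; the difference between the two cores is not broken down here. In a functional assay on VCaP cells (Homo sapiens) for antiproliferative activity, read by propidium iodide staining, with a stated time of 96 h (on this read-out lower numbers stand for stronger inhibition and higher numbers for weaker inhibition), compound 1 gives 32000 nM, compound 2 gives 23800 nM, and compound 3 gives 35500 nM. The change from compound 1 to compound 2 is 2-(trifluoromethyl)phenyl in place of 3-(trifluoromethyl)phenyl on a sulfonyl sulfur, and it made a 1.3-fold lower number from compound 1 to compound 2 (0.13 log units; within the scatter). The same change is made from compound 3 to compound 4: 2-(trifluoromethyl)phenyl in place of 3-(trifluoromethyl)phenyl on a sulfonyl sulfur. Compound 4 has not yet been measured in this assay. Because the step of a 1.3-fold lower number from compound 1 to compound 2 (0.13 log units; within the scatter) stayed within the scatter, the expected step from compound 3 to compound 4 is also small, estimated as a 1.3-fold lower number from compound 3 to compound 4 (0.12 log units; within the scatter). The estimate for compound 4 in this assay is therefore 27000 nM, with a range from 12000 nM to 60000 nM. This expectation rests on a single earlier pair of compounds, so its uncertainty is considerable, and all numbers in this series are high.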

Compound 4, half-maximal inhibitory concentration: 40800 nM
For compound 4 the middle estimate is 1.5-fold (0.18 log units) below the measured one; low and high end bracket the measured number.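

In this assay, placing 2-(trifluoromethyl)phenyl in place of 3-(trifluoromethyl)phenyl on a sulfonyl sulfur made a 1.1-fold higher number from compound 3 to compound 4 (0.06 log units; within the scatter). Set beside the same change on the other core, the two steps do not differ by more than the usual variation between repeated measurements: the same change on two cores in this assay, a 1.3-fold lower number (0.13 log units; within the scatter) from compound 1 to compound 2 and a 1.1-fold higher number (0.06 log units; within the scatter) from compound 3 to compound 4, 1.5-fold (0.19 log units) apart, within the scatter of two such steps. This shows that the change stayed too small to read on both cores, but it does not show that its effect transfers from one core to another, since two steps inside the scatter carry no clear direction that could be compared.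

On these data alone, it remains open whether a nitrile or a carboxylic acid in place of the trifluoromethyl group would give a step large enough to read in this assay. Also open, as far as these compounds go, is whether the same change would stay as small on a core carrying an amine in place of the hydroxyl group.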